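Piperidinyl for Phenyl on a Triazolopyridine Myeloperoxidase Inhibitor

The compounds below may be only part of what the source reports. "The series", "measured", "known", "first", "only" and "open" are said of these compounds alone.

Of the compounds shown here, three sharing one core have been measured in an assay on isolated protein for inhibition of Myeloperoxidase (Homo sapiens), with a stated time of 10 min; a higher number here means a weaker inhibitor, a lower number a stronger inhibitor. Compound 1 `Nc1cc(Cc2ccn(Cc3cccc(-c4ccccc4)c3)n2)c2nn[nH]c2n1` gives 55 nM, the highest of the three numbers. Compound 2 `Nc1cc(Cc2ccn(Cc3ccc4ccccc4c3)n2)c2nn[nH]c2n1` gives 52 nM, which lies within the scatter of compound 1. Compound 3 `Nc1cc([C@H]2CCN[C@H]3C[C@H](Cc4ccccc4)[C@@H](C3)Oc3cccc(c3)Cn3cc2cn3)c2nn[nH]c2n1` gives 5 nM, a clearly lower number than compound 1.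

Compound 4 `Nc1cc(Cc2ccn(Cc3cccc(C4CCNCC4)c3)n2)c2nn[nH]c2n1` differs from compound 1 in a single place: piperidin-4-yl in place of phenyl on an aromatic carbon. Going by the values given here, no measured pair shows this change, so its effect is unknown. The nearest guide is compound 3, whose 5 nM shows that a basic nitrogen in the periphery is compatible with strong inhibition. Compound 4 is therefore expected to give a step of a 1.4-fold lower number from compound 1 to compound 4 (0.14 log units; within the scatter), a modest gain at most. Compound 4 is estimated at 40 nM, between 12 nM and 130 nM.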

Compound 4, half-maximal inhibitory concentration: 100 nM
For compound 4 the middle estimate is 2.5-fold (0.40 log units) below the measured one, within the range that was stated.
By their numbers in this assay, from the lowest: compound 3; then compounds 2, 1 and 4 (each within the scatter of the next).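

In this assay, going by these compounds alone, piperidin-4-yl in place of phenyl on this aromatic carbon gives a 1.8-fold higher number from compound 1 to compound 4 (0.26 log units; within the scatter) and so provides the first measured pair at this position. It shows that the non-aromatic ring with its ring nitrogen cannot be told apart from phenyl here, so the six-membered aromatic ring of carbon only is not required at this place in this assay. Nothing measured here accounts for this result. Still open, as far as these compounds go, is whether an aminomethyl group or a morpholin-4-yl ring on this carbon would also stay within the scatter of phenyl.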